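The source may hold more compounds than are shown below. What is called first, only, known or untested is meant among the compounds shown, and "the series" means these compounds.

Series notes. Two compounds of this set have so far been taken into a functional assay on MIA PaCa-2 cells (Homo sapiens) for inhibition, read by MTT assay, with a stated time of 72 h; on this read-out lower numbers stand for stronger inhibition and higher numbers for weaker inhibition. Compound 1 `Cn1cc(CO)c(N)nc1=O` gives no number there, only a limit, > 100000 nM. Compound 2 `O=c1nc(NO)cc[nH]1` likewise gives only a limit in this assay, > 100000 nM. Both readings thus rest at the same point, (the limit of > 100000 nM in this assay, at which 2 of the 2 values shown sit), so nothing separates the two and compound 2 cannot be placed above or below any other member; it stands at the limit and nowhere else.

Compound 3 `CSc1cc[nH]c(=O)n1` is the next to be measured in this assay. It differs from compound 2 in one place: methylsulfanyl in place of hydroxyamino on an aromatic carbon. Among the measured compounds shown here, no step between measured compounds exists against which such a change could be gauged, and with both known values at the limit the set offers no direction. The expected step that the limit leaves unreadable from compound 2 to compound 3 is accordingly none beyond the scatter. Compound 3 is estimated at 150000 nM, with a range from 40000 nM to 600000 nM, and the assay is expected most likely to report a limit again rather than a number.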

Compound 3, half-maximal inhibitory concentration: > 100000 nM
Compound 3: a limit, no number; the forecaster's own chance of this, stated with the estimate: 85%; the middle value does not contradict the limit.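

Compound 3, like compound 2, gives only a limit in this assay, so no step can be read from compound 2 to compound 3, and methylsulfanyl in place of hydroxyamino stays without a size: the limit of > 100000 nM in this assay, at which 3 of the 3 values shown sit.

The compounds shown leave open whether any change on the shared core gives a number rather than a limit in this assay.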